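Methyl branching in a propargylamine series: whole-animal agonist dose

The compounds below may be only part of what the source reports. "The series", "measured", "known", "first", "only" and "open" are said of these compounds alone.

Measured compounds:
- compound 1 `CC(=O)N(C)C(C)C#CCn1cncc1C`; > 100 mg/kg
- compound 2 `CC(=O)N(C)CC#CCn1cncc1C`; 5.4 mg/kg
- compound 3 `CCOC(=O)N(C)CC#CCN1CCCC1`; 66 mg/kg

The series is read in a functional assay on the whole organism for agonist activity, with Mus musculus as the target; a higher number here means that more compound is needed for the effect, a lower number that less compound is needed. Compound 2 gives 5.4 mg/kg in this assay. Compound 1, in this assay, reaches only a limit, > 100 mg/kg; no number is known for it. Compound 3 gives 66 mg/kg in this assay, which is the highest of the two numbers shown, and its gap to compound 2 lies beyond the scatter. The difference between the cores of compound 2 and compound 3 is not broken down here.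

Within the measured pairs, one step is counted: methyl in place of hydrogen on a saturated chain carbon bound to an amide-type nitrogen and a triple-bonded carbon. It brings an at least 18-fold higher number from compound 2 to compound 1 (1.26 log units; beyond the scatter). The size of this step rests on (the limit of > 100 mg/kg in this assay, at which 1 of the 3 values shown sits), so its true extent is not known.

Within the data shown here, the unmeasured compound 4 `CCOC(=O)N(C)C(C)C#CCN1CCCC1` is reached from compound 3 by methyl in place of hydrogen on a saturated chain carbon bound to an amide-type nitrogen and a triple-bonded carbon, the same kind of change as the one from compound 2 to compound 1, at the same place in words. On that precedent, compound 4 is expected to show a step of a 6.1-fold higher number from compound 3 to compound 4 (0.78 log units; beyond the scatter) in this assay, a rise of the same order, because the only measured case of this change gave an at least 18-fold higher number from compound 2 to compound 1 (1.26 log units; beyond the scatter). Starting from the higher number of compound 3, the expected value for compound 4 is estimated at 400 mg/kg, between 100 mg/kg and 2000 mg/kg, and the assay may well return only a limit for compound 4.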

Compound 4, dose for half-maximal effect: > 100 mg/kg
Compound 4 gave a limit, no number (the forecaster's own chance of this, stated with the estimate: 80%); the middle value is on the limit's open side.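

In this assay compound 4 reaches only a limit (> 100 mg/kg), and no number is known for it. On the core of compound 3, methyl in place of hydrogen gives an at least 1.5-fold higher number from compound 3 to compound 4 (0.18 log units; that floor lies within the scatter) as a floor only, which fits the large step on the other core but does not confirm that it carries over, and the size of the change on the two cores cannot be compared: the same change on two cores in this assay, an at least 18-fold higher number (1.26 log units; beyond the scatter) from compound 2 to compound 1 and an at least 1.5-fold higher number (0.18 log units; that floor lies within the scatter) from compound 3 to compound 4; the limit leaves it open whether they differ. Both methyl-bearing compounds, compound 1 and compound 4, therefore show the same direction at most as far as their limits allow, and neither gives a true size for the change: the limit of > 100 mg/kg in this assay, at which 2 of the 4 values shown sit.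

The compounds shown leave open how much compound the two methyl-bearing members would need for the effect, and thus whether the change costs the same on both cores. They also leave open how an ethyl group or a longer chain would behave on a saturated chain carbon bound to an amide-type nitrogen and a triple-bonded carbon, and whether any such group would return a number rather than a limit.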